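Dropping an Aryl Methyl in a Carbamate Series

The compounds below may be only part of what the source reports. "The series", "measured", "known", "first", "only" and "open" are said of these compounds alone.

Measured compounds:
compound 1 `CCCOC(=O)Nc1ccc([Se]C#N)cc1`, 3700 nM
compound 2 `CC(C)COC(=O)Nc1ccc([Se]C#N)cc1`, 5800 nM
compound 3 `Cc1ccc(OC(=O)Nc2ccc([Se]C#N)cc2)cc1`, 4400 nM

In an ADME assay on 184B5 cells (Homo sapiens) for cytotoxicity, read by MTT assay, with a stated time of 72 h (on this read-out lower numbers stand for stronger inhibition of growth and higher numbers for weaker inhibition of growth), the three measured compounds give numbers that lie close together. Compound 3 sits between compound 1 and compound 2, and both gaps are within the scatter, so no order among the three can be read from these numbers.

Compound 4 `N#C[Se]c1ccc(NC(=O)Oc2ccccc2)cc1` has not been measured. It differs from compound 3 in one place: hydrogen in place of methyl on an aromatic carbon. The change is thus a single methyl removed from the aromatic ring of the carbamate aryl group.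

Among the measured compounds shown here, only one measured step concerns a methyl, a 1.6-fold higher number from compound 1 to compound 2 (0.20 log units; within the scatter), and there the methyl sits on a saturated chain carbon, not on an aromatic carbon. It therefore bears only loosely on the present change, and what it shows is a step within the scatter. For the measured compounds named here, no measured pair tells how an aromatic methyl on this carbamate aryl group affects this assay.

On that basis the account expects no step beyond the scatter, no change at the digits printed from compound 3 to compound 4 (within the scatter), for compound 4 relative to compound 3. Compound 4 is estimated to give 4400 nM in this assay, with a range from 2200 nM to 8800 nM.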

Compound 4, concentration for 50% growth inhibition: 400 nM
The estimate for compound 4 lay 11-fold (1.04 log units) above the measured number, and the stated range ends above it.
By their numbers in this assay, from the lowest: compound 4; then compounds 1, 3 and 2 (each within the scatter of the next).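

Among the compounds shown here, on this aromatic carbon, para to a large group, the exchange of methyl for hydrogen goes with a large change: the result is an 11-fold lower number from compound 3 to compound 4 (1.04 log units; beyond the scatter) in this assay and stands apart from the only earlier methyl step, on a saturated chain carbon, which was a 1.6-fold higher number from compound 1 to compound 2 (0.20 log units; within the scatter) and stayed within the scatter. The unsubstituted phenyl carbamate also separates from both chain carbamates, with a 9.3-fold lower number from compound 1 to compound 4 (0.97 log units; beyond the scatter) and then a 15-fold lower number from compound 2 to compound 4 (1.16 log units; beyond the scatter) as the two further steps, and both lie beyond the scatter, so compound 4 gives the lowest number of the four. Nothing at hand explains why this single methyl carries such weight.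

Whether the step belongs to methyl in particular or to any group on this carbon remains open, since the compounds shown say nothing of a fluorine, a methoxy group or an ethyl group there. They also leave open whether a methyl on another carbon of the same ring would give a number nearer compound 3 or compound 4.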